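The source may hold more compounds than are shown below. What is called first, only, known or untested is meant among the compounds shown, and "the series" means these compounds.

The study set compound 2 `NC1(CCn2ccc(=O)[nH]c2=O)OC(=O)C(OCc2ccccc2)=C1OCc1ccccc1` beside compound 1 `O=C1O/C(=C\Cn2c(=O)[nH]c(=O)[nH]c2=O)C(OCc2ccccc2)=C1OCc1ccccc1` and compound 3 `O=C1O[C@H]([C@@H](O)Cn2c(=O)[nH]c(=O)[nH]c2=O)C(OCc2ccccc2)=C1OCc1ccccc1` in a functional assay on HepG2 cells (Homo sapiens) for inhibition, read by MTT assay, with a stated time of 72 h; a lower number here means a stronger inhibitor, a higher number a weaker inhibitor. Compound 1 gives 44800 nM in this assay. For compound 2 the assay reports only > 100000 nM, which is a limit of the measurement and not a number. Compound 3 likewise reaches only the limit > 100000 nM. Compound 2 thus stands at the limit of > 100000 nM in this assay, at which 2 of the 3 values shown sit, with no measured number of its own. Compound 4 `NC1(CCn2ncc(=O)[nH]c2=O)OC(=O)C(OCc2ccccc2)=C1OCc1ccccc1` is reached from compound 2 by one change: a group of 8 heavy atoms (3 carbon, 3 nitrogen, 2 oxygen; one six-membered aromatic ring with 3 hetero atoms) in place of a group of 8 heavy atoms (4 carbon, 2 nitrogen, 2 oxygen; one six-membered aromatic ring with 2 hetero atoms), on a saturated chain carbon, two bonds along the chain from a saturated ring carbon. Going by the values given here, no measured pair in this set shows the effect of such a change, so no step beyond the scatter can be expected in either direction, and a result again at the limit seems most likely. Compound 4 is therefore expected to give about 150000 nM in this assay, within 50000 nM to 500000 nM. That amounts to an estimated step that the limit leaves unreadable from compound 2 to compound 4.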

Compound 4, half-maximal inhibitory concentration: > 100000 nM
Compound 4 ended at the assay's limit; the forecaster's own chance of this, stated with the estimate: 80%; the middle value lies beyond the limit too.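

Going by these compounds alone, compound 2 and compound 4 both end at a limit in this assay and not at a number, so no step between them can be read. The compounds shown leave open how the six-membered aromatic ring with 3 hetero atoms compares in inhibition with the one with 2 hetero atoms.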